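From hexyl to cyclohexyl on the shared core

The compounds below may be only part of what the source reports. "The series", "measured", "known", "first", "only" and "open" are said of these compounds alone.

Compound 1 `CCCCCCc1nc(-c2ccc(CNC(=O)[C@H]3NCC[C@@H]3O)cc2)no1` gives > 50 ug/mL as a limit
Compound 2 `CCCCCCCc1nc(-c2ccc([C@@H](NC(=O)[C@H]3NCC[C@@H]3O)C(C)C)cc2)no1` gives 3 ug/mL as a number

Both readings come from a physicochemical assay for solubility, at pH 7.4 (a higher number here means a more soluble compound, a lower number a less soluble compound), and differ in more than one place of the structure. Compound 1 stands at a limit and not on a number, as the limit of > 50 ug/mL in this assay, at which 1 of the 2 values shown sits, shows.

For the measured compounds named here, compound 3 `O=C(NCc1ccc(-c2noc(C3CCCCC3)n2)cc1)[C@H]1NCC[C@@H]1O` keeps the core of compound 1 and carries cyclohexyl in place of hexyl on an aromatic carbon in the one change between them. Going by the values given here, no measured step shows what such a change does in this assay here, so the expectation rests on compound 1 alone, whose > 50 ug/mL is a limit of the assay. A small downward step is expected, an at least 1.2-fold lower number from compound 1 to compound 3 (0.09 log units; that floor lies within the scatter) as estimated, and it may not go beyond the scatter. For compound 3 the expected value is 40 ug/mL in an estimated range from 14 ug/mL to 70 ug/mL for this measurement.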

Compound 3, solubility: > 50 ug/mL
Compound 3 was reported as a limit; the forecaster's own chance of this, stated with the estimate: 50%; at least 1.2-fold (0.09 log units) between middle value and limit.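

Compound 3 and compound 1 both stand at a limit in this assay, so no step between them can be read: the limit of > 50 ug/mL in this assay, at which 2 of the 3 values shown sit.

The compounds shown leave open whether cyclohexyl in place of hexyl on an aromatic carbon changes the reading in this assay at all, and by how much.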